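Series notes: hydroxyethyl for methyl on the amide-bearing carbon

The source may report more compounds than this note shows. Statements on the series, on what has been measured and on what is new or still open speak of the compounds shown alone.

Measured so far:
compound 1, `C[C@H](NC(=O)CN(c1nc(Cl)nc2[nH]cnc12)C1CC1)C(=O)OCc1ccccc1`, 36.1%
compound 2, `O=C(O)[C@@H]1CCCN1C(=O)CN(c1nc(Cl)nc2[nH]cnc12)C1CC1`, 23.6%

In a functional assay on the whole organism (Tail, strain ICR) with Mus musculus as the target, in the tail flick test, with a stated time of 120 min, at a dose of 25 umol/kg by the oral route (on this read-out lower numbers stand for a weaker effect and higher numbers for a stronger effect at the one dose given), compound 1 gives 36.1%, the higher of the two numbers; compound 2 gives 23.6%, a gap that lies beyond the scatter. Within the data shown here, compound 1 and compound 2 differ in more than one place, so no single step between them is set out, and only their two values are on hand.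

Compound 3, `C[C@@H](O)[C@H](NC(=O)CN(c1nc(Cl)nc2[nH]cnc12)C1CC1)C(=O)OCc1ccccc1`, is not yet measured. It differs from compound 1 by 1-hydroxyethyl in place of methyl on a saturated chain carbon bound to an amide-type nitrogen and a carbonyl carbon. Among the measured compounds shown here, no step of this kind has been measured, so the expectation rests on compound 1 alone. A small step is expected, if anything downward, and most likely within the scatter, since the change keeps everything else of compound 1 in place. For compound 3 the expected step is a number 6.1 percentage points lower from compound 1 to compound 3 (within the scatter), and the estimated value is 30%, within a range of 15% to 45%.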

Compound 3, a percentage reported as activity, at one dose (the size of the read-out at that dose, not a potency): 30.7%
Beside the measured number, compound 3's estimate is 0.7 percentage points below it, and the stated range covers the measured number.
By their numbers in this assay, from the lowest: compounds 2, 3 and 1 (each within the scatter of the next, the first and the last beyond it).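

In this assay, among these compounds, the first measured change on the saturated chain carbon bound to an amide-type nitrogen and a carbonyl carbon reads a number 5.4 percentage points lower from compound 1 to compound 3 (within the scatter). This position therefore accepts 1-hydroxyethyl in place of methyl, with the added hydrogen-bond donor, hydrogen-bond acceptor and defined stereocentre, and the two values cannot be told apart at this single dose and time. Nothing on hand gives a cause for this result.

Still open, going by these compounds, is whether an amine or a longer chain on this carbon would also stay within the scatter of compound 1, and whether the other configuration of the 1-hydroxyethyl stereocentre would read the same. Also unsettled is whether the same step would hold at other doses or times.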